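A few compounds are considered here, and "the series" means these few. Any claim that something is new, unique, unknown or untested is made for them only; others in the source may bear on it.

The three measured compounds share one core. Compound 1 `CC1=C(C(=O)Nc2ccc(Br)cc2)C(c2ccc(Cl)cc2Cl)N=C(SCc2ccccc2)N1` gives 1.5% in a functional assay on the whole organism (artery, strain albino) with Rattus norvegicus as the target, with a stated time of 15 min, at a dose of 10 mg/kg by the oral route; on this read-out lower numbers stand for less inhibition and higher numbers for more inhibition at the one dose given (going by the name of the read-out). Compound 2 `CC1=C(C(=O)Nc2ccc(Br)cc2)C(c2ccc(Cl)cc2Cl)N=C(SCc2ccc(F)cc2)N1` gives 3.6% in the same read-out, the step of a number 2.1 percentage points higher from compound 1 to compound 2 (within the scatter) belonging to fluoro in place of hydrogen on an aromatic carbon. Compound 3 `COc1ccc(C2N=C(SCc3ccccc3)NC(C)=C2C(=O)Nc2ccc(Br)cc2)cc1` gives 1%; the step of a number 0.5 percentage points lower from compound 1 to compound 3 (within the scatter) belongs to 4-methoxyphenyl in place of 2,4-dichlorophenyl on a saturated ring carbon. Compound 3 therefore sits alongside compound 1 and compound 2, its gaps to both lying within the scatter, so no ordering among the three can be claimed.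

Compound 4 `COc1ccc(C2N=C(SCc3cccc(Cl)c3)NC(C)=C2C(=O)Nc2ccc(Br)cc2)cc1` differs from compound 3 by chloro in place of hydrogen on an aromatic carbon. For the measured compounds named here, the only measured step that bears on a halogen entering this aromatic ring is a number 2.1 percentage points higher from compound 1 to compound 2 (within the scatter), which stayed within the scatter. On that basis no movement beyond the scatter is expected for compound 4, the expected step being a number 1 percentage points higher from compound 3 to compound 4 (within the scatter). Compound 4 is estimated at 2%, with a range from 0% to 8%.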

Compound 4, a percentage reported as inhibition, in the whole organism at one dose (the size of the read-out at that dose, not a potency): 3.1%
Compound 4: middle estimate off by 1.1 percentage points, on the low side; low and high end bracket the measured number.
By their numbers in this assay, from the lowest: compounds 3, 1, 4 and 2 (each within the scatter of the next).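

With chloro entering as 3-chlorobenzyl in place of benzyl on the sulfur, a number 2.1 percentage points higher from compound 3 to compound 4 (within the scatter) in this assay extends the earlier finding to a second halogen, placed meta to a large group. The step also comes from compound 3, which carries 4-methoxyphenyl on the saturated ring carbon, so this small change on the benzyl ring stayed within the scatter with either of the two aryl groups at that carbon, although chloro was tried only with 4-methoxyphenyl. No measurement on hand accounts for the size of this step.

All four numbers lie close together, and no step shown goes beyond the scatter, so it remains open whether this ring can change the read-out at all. An amine or a carboxylic acid on the benzyl ring, or a longer chain in place of the benzyl group, would test that.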